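Aryl substitution on the ring amine of the shared core

The source may hold more compounds than are shown below. What is called first, only, known or untested is meant among the compounds shown, and "the series" means these compounds.

Measured compounds:
compound 1 `Clc1cc(Cl)cc(CO[C@H]2CCCN(Cc3cccnc3)[C@H]2c2ccccc2)c1` — 112000 nM
compound 2 `Clc1cc(Cl)cc(CO[C@H]2CCCN(Cc3ccc(-c4nn[nH]n4)cc3)[C@H]2c2ccccc2)c1` — 74000 nM
compound 3 `CN1CCC[C@H](OCc2cc(Cl)cc(Cl)c2)[C@@H]1c1ccccc1` — > 200000 nM

For the measured compounds named here, in an assay on isolated protein for activation of cGMP-dependent protein kinase 1 (Homo sapiens), read by ADP-Glo, with stated times of 120 min and 40 min (on this read-out lower numbers stand for an effect already at smaller amounts and higher numbers for an effect only at larger amounts of compound), compound 3 gives only a limit, > 200000 nM, not a number; it is the one of the three values sitting at the limit of > 200000 nM in this assay, at which 1 of the 3 values shown sits. In this assay compound 1 gives 112000 nM and compound 2 gives 74000 nM.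

Compound 4 `Cn1ccnc1CN1CCC[C@H](OCc2cc(Cl)cc(Cl)c2)[C@@H]1c1ccccc1` differs from compound 3 by 1-methyl-1H-imidazol-2-yl in place of hydrogen on a saturated chain carbon bound to an amine nitrogen in a ring.

Going by the values given here, two measured steps bear on this change, both running the other way: an at least 1.7-fold higher number from compound 1 to compound 3 (0.25 log units; that floor lies within the scatter) and an at least 2.7-fold higher number from compound 2 to compound 3 (0.43 log units; beyond the scatter). Placing a ring on the saturated chain carbon bound to the ring amine nitrogen therefore brought the number down from the limit of compound 3 in both cases, the pair with compound 2 beyond the scatter. For compound 4 a step down of similar size is expected, an at least 1.6-fold lower number from compound 3 to compound 4 (0.22 log units; that floor lies within the scatter), since the entering 1-methyl-1H-imidazol-2-yl is again an aromatic ring at that place. Compound 4 is thus estimated at 120000 nM, with a range from 50000 nM to 250000 nM.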

Compound 4, half-maximal effective concentration: 165000 nM
The estimate for compound 4 lay 1.4-fold (0.14 log units) below the measured number; the range from low to high includes it.
By their numbers in this assay, from the lowest: compounds 2, 1 and 4 (each within the scatter of the next, the first and the last beyond it). At a limit, above all of these: compound 3.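

Compound 3 remains a limit, not a number: the limit of > 200000 nM in this assay, at which 1 of the 4 values shown sits.

In this assay, the 1-methyl-1H-imidazol-2-yl group gives an at least 1.2-fold lower number from compound 3 to compound 4 (0.08 log units; that floor lies within the scatter), so this ring is not shown to differ from hydrogen at this place. Among the aromatic groups on the saturated chain carbon bound to the ring amine nitrogen, it is separated from 4-(2H-tetrazol-5-yl)phenyl, with a 2.2-fold higher number from compound 2 to compound 4 (0.35 log units; beyond the scatter), but not from pyridin-3-yl, with a 1.5-fold higher number from compound 1 to compound 4 (0.17 log units; within the scatter).

From the compounds shown here alone, it remains open whether the 2H-tetrazol-5-yl part of compound 2 is what sets it apart, and a carboxylic acid on that phenyl ring would test this. A longer chain carrying the aromatic ring on the ring amine nitrogen is also untested in the compounds shown here.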